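This account rests on a few compounds, and the source may have more. Where it says the series, first, only, none or still open, it means among the compounds named here.

Of the compounds shown here, three built on one shared core have been measured in a functional assay on MCF7 cells (Homo sapiens) for antiproliferative activity, read by MTT assay, with a stated time of 48 h; a higher number here means a weaker inhibitor, a lower number a stronger inhibitor. Compound 1 `O=C(/C=C/c1cccc(NC(=O)c2ccccc2Cl)c1)c1nc2ccccc2[nH]1` gives 4570 nM, compound 2 `Cc1ccccc1C(=O)Nc1cccc(/C=C/C(=O)c2nc3ccccc3[nH]2)c1` gives 5870 nM, and compound 3 `Cc1cc(C)cc(C(=O)Nc2cccc(/C=C/C(=O)c3nc4ccccc4[nH]3)c2)c1` gives 24600 nM, the highest of the three numbers. Compound 4 `Cc1ccccc1S(=O)(=O)Nc1cccc(/C=C/C(=O)c2nc3ccccc3[nH]2)c1` carries (2-methylphenyl)sulfonyl in place of (3,5-dimethylphenyl)carbonyl on a nitrogen on an aromatic ring. For the measured compounds named here, two measured steps bear on this position: a 5.4-fold higher number from compound 1 to compound 3 (0.73 log units; beyond the scatter) and a 4.2-fold higher number from compound 2 to compound 3 (0.62 log units; beyond the scatter), so both the 2-chlorophenyl and the 2-methylphenyl carbonyl gave lower numbers than the 3,5-dimethylphenyl carbonyl, while a 1.3-fold higher number from compound 1 to compound 2 (0.11 log units; within the scatter). Going by the values given here, compound 4 brings back the 2-methylphenyl of compound 2 but on a sulfonyl rather than a carbonyl, a swap no measured pair covers. Compound 4 is therefore expected to give a lower number, a 3.1-fold lower number from compound 3 to compound 4 (0.49 log units; beyond the scatter). The estimate for compound 4 is 8000 nM, with a range from 2500 nM to 25000 nM.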

Compound 4, half-maximal inhibitory concentration: 4130 nM
Compound 4: middle estimate off by 1.9-fold (0.29 log units), on the high side; the range from low to high includes it.
By their numbers in this assay, from the lowest: compounds 4, 1 and 2 (each within the scatter of the next); then compound 3.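

In this assay, with the 2-methylphenyl group kept, putting a sulfonyl in place of the carbonyl on this nitrogen gives a 1.4-fold lower number from compound 2 to compound 4 (0.15 log units; within the scatter), so the change of linking group alone does not move the number beyond the scatter. Compared with the 2-chlorophenyl carbonyl, the result is similar, with a 1.1-fold lower number from compound 1 to compound 4 (0.04 log units; within the scatter), whereas the 3,5-dimethylphenyl carbonyl stands apart, with a 6.0-fold lower number from compound 3 to compound 4 (0.77 log units; beyond the scatter). No measurement shown gives a reason for these results. Going by these compounds, whether a sulfonyl holds this level with 2-chlorophenyl or 3,5-dimethylphenyl remains open, as does the effect of a longer chain or an amine in place of the aromatic ring on the sulfonyl.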